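Notes on the bromobenzyl piperazine sulfonamides

The source may report more compounds than this note shows. Statements on the series, on what has been measured and on what is new or still open speak of the compounds shown alone.

Measured so far in an assay on CHO cells for displacement of a labelled ligand from adenosine receptor A3 (Homo sapiens), read by scintillation counting, with a stated time of 45 min, tested at 1 uM, in the presence of a further agent that is not named here; on this read-out higher numbers stand for more inhibition at the one concentration tested (going by the name of the read-out) and lower numbers for less inhibition:
compound 1 `CCCn1c(=O)[nH]c2nc(-c3ccc(S(=O)(=O)N4CCN(c5ccccc5C)CC4)cc3)[nH]c2c1=O` gives 25%
compound 2 `CCCn1c(=O)[nH]c2nc(-c3ccc(S(=O)(=O)N4CCN(Cc5cccc(Br)c5)CC4)cc3)[nH]c2c1=O` gives 23%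
compound 3 `CCCn1c(=O)[nH]c2nc(-c3ccc(S(=O)(=O)N4CCN(Cc5ccc(Br)c(F)c5)CC4)cc3)[nH]c2c1=O` gives 27%

All three share one core and differ only on the amine nitrogen in the ring. Compound 2 sits in one band with the others: the step of a number 2 percentage points lower from compound 1 to compound 2 (within the scatter) and the step of a number 4 percentage points higher from compound 2 to compound 3 (within the scatter) are both within the scatter, as is a number 2 percentage points higher from compound 1 to compound 3 (within the scatter), so the three numbers cannot be told apart.

Compound 4 `CCCn1c(=O)[nH]c2nc(-c3ccc(S(=O)(=O)N4CCN(Cc5ccc(Br)cc5)CC4)cc3)[nH]c2c1=O` is not yet measured. It differs from compound 2 as follows: 4-bromophenyl in place of 3-bromophenyl on a saturated chain carbon bound to an amine nitrogen in a ring. The step that bears most directly on this is a number 4 percentage points higher from compound 2 to compound 3 (within the scatter), which also exchanges one bromophenyl for another on the same saturated chain carbon and stays within the scatter. The step of a number 2 percentage points lower from compound 1 to compound 2 (within the scatter) likewise shows that changing the group on that nitrogen left the number flat. No step beyond the scatter is therefore expected, in either direction. The estimate for compound 4 is 24%, with a range from 12% to 38%, which is expected to mean a step of a number 1 percentage points higher from compound 2 to compound 4 (within the scatter).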

Compound 4, a percentage reported as inhibition, at one concentration (the size of the read-out at that concentration, not a potency): 28%
Beside the measured number, compound 4's estimate is 4 percentage points below it; the range from low to high includes it.
By their numbers in this assay, from the lowest: compounds 2, 1, 3 and 4 (each within the scatter of the next).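

In this assay, the exchange of 3-bromobenzyl for 4-bromobenzyl, taken alone at this position, gives a number 5 percentage points higher from compound 2 to compound 4 (within the scatter) and so does not separate the two bromobenzyl groups. Hydrogen in place of fluoro on the aromatic carbon gives a number 1 percentage points higher from compound 3 to compound 4 (within the scatter) and shows that the fluoro can go without a readable step, while 4-bromobenzyl in place of 2-methylphenyl gives a number 3 percentage points higher from compound 1 to compound 4 (within the scatter) and keeps all four compounds in one band. No supporting data bear on this result.

Left open is whether a carboxylic acid or an amine in place of the bromine, or a longer chain in place of the benzyl group, would carry the number out of this band. On these data alone, with one tested concentration for each compound, any difference in potency among the four also stays open.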